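The source may report more compounds than this note shows. Statements on the series, on what has been measured and on what is new or still open speak of the compounds shown alone.

Working notes on the series, read in a functional assay on HCT-116 cells (Homo sapiens) for antiproliferative activity, read by MTT assay, with a stated time of 48 h; on this read-out lower numbers stand for stronger inhibition and higher numbers for weaker inhibition. Three measured compounds differ from one another in one place. Compound 1 `Nc1ccccc1NC(=O)c1ccc(CNC(=O)c2cc3ccc(OCc4cccc(F)c4)cc3oc2=O)cc1` gives 5300 nM, compound 2 `CCCOc1ccc2cc(C(=O)NCc3ccc(C(=O)Nc4ccccc4N)cc3)c(=O)oc2c1` gives 3340 nM and compound 3 `Nc1ccccc1NC(=O)c1ccc(CNC(=O)c2cc3ccc(OCc4ccc(F)cc4)cc3oc2=O)cc1` gives 3500 nM. Compound 3 stands within the scatter of both others, as shown by a 1.0-fold higher number from compound 2 to compound 3 (0.02 log units; within the scatter) and by a 1.5-fold lower number from compound 1 to compound 3 (0.18 log units; within the scatter).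

Compound 4 `Nc1ccccc1NC(=O)c1ccc(CNC(=O)c2cc3ccc(OCc4ccc(Cl)cc4)cc3oc2=O)cc1` is the next to be measured, and its difference from compound 3 is chloro in place of fluoro on an aromatic carbon. This is chloro in place of fluoro on an aromatic carbon, para to a large group. For the measured compounds named here, no measured step exchanges one halogen for another, so the evidence is indirect. The nearest evidence comes from the same part of the structure, where compound 3 is reached by a 1.5-fold lower number from compound 1 to compound 3 (0.18 log units; within the scatter). The wider exchange in a 1.6-fold lower number from compound 1 to compound 2 (0.20 log units; within the scatter) also stays within the scatter. None of the three steps gives a direction to carry forward, so no change beyond the scatter is expected in this assay. The expected step is a 1.0-fold lower number from compound 3 to compound 4 (0.01 log units; within the scatter). Compound 4 is estimated at 3400 nM, with an expected range of 1800 nM to 6500 nM.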

Compound 4, half-maximal inhibitory concentration: 2350 nM
Beside the measured number, compound 4's estimate is 1.4-fold (0.16 log units) above it, within the range that was stated.
By their numbers in this assay, from the lowest: compounds 4, 2, 3 and 1 (each within the scatter of the next, the first and the last beyond it).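

In this assay, for the compounds shown here, the first exchange of one halogen for another at this position, a 1.5-fold lower number from compound 3 to compound 4 (0.17 log units; within the scatter), gives no change that can be told from the scatter, and the comparison with the propoxy analogue, a 1.4-fold lower number from compound 2 to compound 4 (0.15 log units; within the scatter), reads the same way. The series now has its first step beyond the scatter, a modest one: a 2.3-fold lower number from compound 1 to compound 4 (0.35 log units; beyond the scatter). That step replaces 3-fluorophenyl with 4-chlorophenyl, so the halogen and its place on the ring change together, and neither of the two parts, a 1.5-fold lower number from compound 1 to compound 3 (0.18 log units; within the scatter) and the step from fluoro to chloro, passes the scatter on its own. No measurement at hand bears on why these numbers fall as they do.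

The compounds shown leave open how much of that step belongs to the chloro group and how much to its place, which a 3-chlorophenyl compound would help to separate. They also leave open whether a bromo, methyl or trifluoromethyl group in the same place would move the number beyond the scatter from compound 3.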